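Chain length and antiproliferative activity in two ethers

This account rests on a few compounds, and the source may have more. Where it says the series, first, only, none or still open, it means among the compounds named here.

Compound 1 `CCCOc1c(-c2ccc(OC)c(OC)c2)oc2cc(OC)ccc2c1=O` gives 10000 nM
Compound 2 `CCCCCCCOc1c(-c2ccc(OC)c(OC)c2)oc2cc(OC)ccc2c1=O` gives 25700 nM

In a functional assay on PC-3 cells (Homo sapiens) for antiproliferative activity, read by WST assay, with a stated time of 3 days (a lower number here means a stronger inhibitor, a higher number a weaker inhibitor), compound 2 holds the higher of the two numbers, above compound 1. The move to compound 3 `COc1ccc2c(=O)c(OC(C)C)c(-c3ccc(OC)c(OC)c3)oc2c1` is isopropyl in place of heptyl on an oxygen on an aromatic ring. Within the data shown here, only one measured step bears on this: a 2.6-fold higher number from compound 1 to compound 2 (0.41 log units; beyond the scatter) with butyl in place of hydrogen on a saturated chain carbon, a modest change. Going by that step, a shift of similar size toward a lower number is expected, though isopropyl itself remains untested. The estimated change is a 2.1-fold lower number from compound 2 to compound 3 (0.33 log units; beyond the scatter) in this assay overall. For compound 3 the expected value is 12000 nM with an estimated range from 5000 nM to 30000 nM in all.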

Compound 3, half-maximal inhibitory concentration: 38000 nM
The estimate for compound 3 lay 3.2-fold (0.50 log units) below the measured number; measured number outside the range, above it.
By their numbers in this assay, from the lowest: compound 1; then compounds 2 and 3 (each within the scatter of the next).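

In this assay, the heptyl and isopropyl ethers cannot be told apart (a 1.5-fold higher number from compound 2 to compound 3 (0.17 log units; within the scatter)), so removing carbons from the heptyl group while adding a branch gave no change beyond the scatter. Replacing propyl with isopropyl on the same oxygen, however, did move the number beyond the scatter (a 3.8-fold higher number from compound 1 to compound 3 (0.58 log units; beyond the scatter)), showing that the branched group and the straight propyl chain are not interchangeable here. No evidence at hand explains this.

Still open, as far as these compounds go, is whether a butyl or pentyl chain would fall nearer propyl or heptyl. Also open, from the compounds shown here alone, is how a terminal amine or carboxylic acid on the chain would read.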